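The source may hold more compounds than are shown below. What is called first, only, known or untested is meant among the compounds shown, and "the series" means these compounds.

Compounds measured in a functional assay on the whole organism (strain Wistar) with Rattus norvegicus as the target, with a stated time of 15 days, at a dose of 10 mg/kg by the oral route; a higher number here means a stronger effect of the compound at the dose given, a lower number a weaker effect:
compound 1, `Cc1nc(COc2ccc(/C=C3\SC(=O)NC3=O)cc2)cs1` — 19.2%
compound 2, `O=C1NC(=O)/C(=C/c2ccc(OCc3csc(-c4ccccc4)n3)cc2)S1` — 21.7%
compound 3, `O=C1NC(=O)/C(=C/c2ccc(OCCSc3nnc(Cc4ccccc4)[nH]3)cc2)S1` — 22.8%

Compound 3 gives the highest of the three numbers, yet its gap to compound 2 and to compound 1 stays within the usual scatter, so the three cannot be ordered. For the measured compounds named here, the only step between compounds that differ in one place, a number 2.5 percentage points higher from compound 1 to compound 2 (within the scatter), brought phenyl in place of methyl and also stayed within the scatter. Compound 4, `O=C1NC(=O)/C(=C/c2ccc(OCCSc3nnc(-c4ccccc4[N+](=O)[O-])[nH]3)cc2)S1`, differs from compound 3 by 2-nitrophenyl in place of benzyl on an aromatic carbon. Going by the values given here, no measured step matches this exchange, and the one step known was flat, so the step of a number 0.8 percentage points lower from compound 3 to compound 4 (within the scatter) is expected to stay within the scatter. Compound 4 is therefore estimated at 22%, with a range from 12% to 32%.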

Compound 4, a percentage reported as activity, at one dose (the size of the read-out at that dose, not a potency): 20.9%
Beside the measured number, compound 4's estimate is 1.1 percentage points above it; the measured number falls inside the stated range.
By their numbers in this assay, from the lowest: compounds 1, 4, 2 and 3 (each within the scatter of the next).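

In this assay, placing 2-nitrophenyl in place of benzyl on the aromatic carbon of the five-membered ring gave a number 1.9 percentage points lower from compound 3 to compound 4 (within the scatter). At this position, then, an aromatic ring attached directly and carrying hydrogen-bond acceptors reads the same, within the scatter, as the benzyl group, which has none. No measurement shown here accounts for this result.

Going by these compounds, whether an amine or a carboxylic acid on this aromatic carbon would move the number beyond the scatter stays open. So does whether a longer chain there would.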